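The compounds below may be only part of what the source reports. "The series", "measured", "known", "first", "only" and "open" are said of these compounds alone.

Compound 3 `O=C(O)CCCCOc1cc(-c2ccccc2)cc(-c2ccccc2)n1` stands lowest of the three numbers measured in an assay on cell membranes from spleen (Cavia porcellus) for binding affinity to leukotriene B4 receptor 1 (Homo sapiens) (a higher number here means a weaker inhibitor, a lower number a stronger inhibitor), where compound 3 gives 50 nM. Compound 1 `O=C(O)CCCOc1cc(-c2ccccc2)cc(-c2ccccc2)n1` gives 300 nM and compound 2 `COc1ccc(-c2cc(-c3ccccc3)cc(OCCCCCC(=O)O)n2)cc1` gives 1000 nM. The change to compound 4 `O=C(O)CCCCCOc1cc(-c2ccccc2)cc(-c2ccccc2)n1` is carboxymethyl in place of carboxy on a saturated chain carbon, four bonds along the chain from an oxygen on an aromatic ring. Among the compounds with values here, the one step that bears on it is the same kind of lengthening one bond nearer the ring, a 6.0-fold lower number from compound 1 to compound 3 (0.78 log units; beyond the scatter). Compound 2 carries the chain of compound 4 but also a methoxy, so its number speaks only loosely. A further modest drop, or at most no change beyond the scatter, is expected; the estimated step is a 1.7-fold lower number from compound 3 to compound 4 (0.22 log units; within the scatter). Compound 4 is therefore expected to give about 30 nM, within 10 nM to 100 nM.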

Compound 4, half-maximal inhibitory concentration: 3 nM
Estimate against measurement, compound 4: 10-fold (1.00 log units) above, outside the stated range (below it).
By their numbers in this assay, from the lowest: compound 4; then compound 3; then compound 1; then compound 2.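

In this assay the lengthening at this position does not level off at compound 3: a 17-fold lower number from compound 3 to compound 4 (1.22 log units; beyond the scatter) is a large step where a 6.0-fold lower number from compound 1 to compound 3 (0.78 log units; beyond the scatter) was modest, and the two together come to a 100-fold lower number from compound 1 to compound 4 (2.00 log units; beyond the scatter) overall. With this chain kept, hydrogen in place of methoxy on an aromatic carbon gives a 330-fold lower number from compound 2 to compound 4 (2.52 log units; beyond the scatter) as well, so that group matters a great deal here. As far as these compounds go, whether a longer chain lowers the number further or raises it stays open, as does the effect of an amide in place of the carboxylic acid. Nothing measured here accounts for these steps.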